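An Allyl Group Enters the Five-Membered Ring of Compound 2

The source may report more compounds than this note shows. Statements on the series, on what has been measured and on what is new or still open speak of the compounds shown alone.

Compound 2 `C[C@H](NC(=O)c1cnnn1Cc1ccc(C(F)(F)F)cc1)c1ccc(C(=O)O)cc1` is measured in a functional assay on CHO cells for antagonist activity at prostaglandin E2 receptor EP4 subtype (Homo sapiens), read by calcium flux, with a stated time of 15 min (on this read-out higher numbers stand for weaker inhibition and lower numbers for stronger inhibition), only as a limit, > 10000 nM. Compound 1 `C[C@H](NC(=O)c1nnn(Cc2ccc(C(F)(F)F)cc2)c1-c1ccccc1)c1ccc(C(=O)O)cc1` likewise gives only a limit, > 10000 nM. Two of the three values shown are therefore set by the limit of > 10000 nM in this assay, at which 2 of the 3 values shown sit. Compound 3 `C[C@H](NC(=O)c1c(-c2ccccc2)nnn1Cc1cccc(C(F)(F)F)c1)c1ccc(C(=O)O)cc1` alone gives a number, 23 nM, showing that the shared core can reach measurable inhibition in this assay. Compound 4 `C=CCc1nnn(Cc2ccc(C(F)(F)F)cc2)c1C(=O)N[C@@H](C)c1ccc(C(=O)O)cc1` differs from compound 2 by allyl in place of hydrogen on an aromatic carbon. Among the measured compounds shown here, no step of this kind has been measured here, so its size is open. Compound 2 rests at the limit, so any measurable move can only be toward stronger inhibition. Compound 4 is expected to give 500 nM, in the range 50 nM to 10000 nM. This estimate means an expected step of an at least 20-fold lower number from compound 2 to compound 4 (1.30 log units; beyond the scatter).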

Compound 4, half-maximal inhibitory concentration: > 1000 nM
Compound 4 was reported as a limit; the forecaster's own chance of this, stated with the estimate: 30%; middle value at least 2.0-fold (0.30 log units) away from the limit.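

Compound 2 and compound 4 are both reported only as limits, and the step between them cannot be read. The compounds shown leave open whether allyl in place of hydrogen changes inhibition at all.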